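The compounds below may be only part of what the source reports. "The series", "measured", "known", "first", "only" and "open" are said of these compounds alone.

Three measured compounds share one core, differing only in the ring that hangs from the carbon with a double bond to nitrogen. In a functional assay on PC-3 cells (Homo sapiens) for inhibition (on this read-out lower numbers stand for stronger inhibition and higher numbers for weaker inhibition), compound 1 `Cc1c(C(=O)N/N=C\c2c(O)cccc2F)oc2cccc(O)c12` gives 8050 nM and compound 2 `Cc1c(C(=O)N/N=C\c2c(O)cccc2Cl)oc2cccc(O)c12` gives 18700 nM, the step being a 2.3-fold higher number from compound 1 to compound 2 (0.37 log units; beyond the scatter). Compound 3 `Cc1ccc(O)c(/C=N\NC(=O)c2oc3cccc(O)c3c2C)c1` gives 7350 nM in this assay, the lowest of the three numbers, though its step from compound 1 is a 1.1-fold lower number from compound 1 to compound 3 (0.04 log units; within the scatter), so those two cannot be told apart; only its step from compound 2, a 2.5-fold lower number from compound 2 to compound 3 (0.41 log units; beyond the scatter), stands clear of the scatter.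

Compound 4 `Cc1c(C(=O)N/N=C\c2cccnc2)oc2cccc(O)c12` is the next to be measured. Its change from compound 3 is pyridin-3-yl in place of 2-hydroxy-5-methylphenyl on a carbon with a double bond to nitrogen. Going by the values given here, no measured step tests this change: every step seen so far keeps the hydroxy group on that ring and alters only the other substituent, so the bearing of those steps, all modest or within scatter, is indirect. Compound 4 is expected to show a step in this assay of a 2.0-fold higher number from compound 3 to compound 4 (0.31 log units; beyond the scatter), with wide uncertainty. The estimate for compound 4 in this assay is 15000 nM, with a range from 5000 nM to 50000 nM.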

Compound 4, half-maximal inhibitory concentration: >= 40000 nM
Compound 4 was reported as a limit; the forecaster's own chance of this, stated with the estimate: 20%; middle value at least 2.6-fold (0.42 log units) from the limit.
By their numbers in this assay, from the lowest: compounds 3 and 1 (each within the scatter of the next); then compound 2. At a limit, above all of these: compound 4.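

In this assay compound 4 is reported as a limit and not as a number: the limit of >= 40000 nM in this assay, at which 1 of the 4 values shown sits. The earlier compounds shown here all keep a hydroxy group on the ring and vary only its other substituent, whereas this change replaces the whole ring, and the shift is beyond the scatter against each of them: an at least 5.4-fold higher number from compound 3 to compound 4 (0.73 log units; beyond the scatter), an at least 4.9-fold higher number from compound 1 to compound 4 (0.69 log units; beyond the scatter) and an at least 2.1-fold higher number from compound 2 to compound 4 (0.33 log units; beyond the scatter). This position on the carbon with a double bond to nitrogen therefore does not treat these rings alike: 2-hydroxy-5-methylphenyl has 1 hydrogen-bond donor and a ring of carbon only, while pyridin-3-yl has 0 hydrogen-bond donors and a ring with 1 hetero atom.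

Those differences all arrive in a single step, so the compounds shown cannot say whether losing the hydroxy group, gaining the ring nitrogen or losing the methyl group matters most, and the limit hides how large the true step is. A plain phenyl ring would separate the hydroxy group from the ring nitrogen, and a 2-hydroxypyridine ring or an amine on the ring remains an open question at this position.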